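This account rests on a few compounds, and the source may have more. Where it says the series, first, only, none or still open, it means among the compounds named here.

Measured so far: compound 1 `CC[C@H](NC(=O)c1c(CN2CCN(C(C)C)CC2)c(-c2ccccc2)nc2ccccc12)c1ccccc1` with 5.7 nM in an assay on cell membranes for displacement of a labelled ligand from Substance-K receptor (Homo sapiens); on this read-out lower numbers stand for stronger inhibition and higher numbers for weaker inhibition; compound 2 `CC[C@H](NC(=O)c1c(CN2CCN(C3CCCCC3)CC2)c(-c2ccccc2)nc2ccccc12)c1ccccc1` with 1.6 nM; compound 3 `C[C@H](NC(=O)c1c(CN2CCC(N)CC2)c(-c2ccccc2)nc2ccccc12)C1CCCCC1` with 33 nM.

Compound 3 shows the highest number of the three; its nearest neighbour is compound 1 and its furthest compound 2, both gaps beyond the scatter. Compound 4 `CC(C)C(=O)N1CCN(Cc2c(-c3ccccc3)nc3ccccc3c2C(=O)N[C@@H](C)C2CCCCC2)CC1` differs from compound 3 by 4-(isopropylcarbonyl)piperazin-1-yl in place of 4-aminopiperidin-1-yl on a saturated chain carbon bound to an aromatic carbon. Among the measured compounds shown here, no measured step covers this change. The only step shown, a 3.6-fold lower number from compound 1 to compound 2 (0.55 log units; beyond the scatter), alters the group on the piperazine nitrogen and was modest. Compounds 1 and 2, both carrying a substituted piperazine, give lower numbers than compound 3, though they also differ elsewhere from it. Compound 4 is therefore expected to give a somewhat lower number, a 2.2-fold lower number from compound 3 to compound 4 (0.34 log units; beyond the scatter), with an estimate of 15 nM and a range from 4 nM to 60 nM.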

Compound 4, inhibition constant: 1.2 nM
Compound 4: middle estimate off by 13-fold (1.10 log units), on the high side, and the stated range ends above it.
By their numbers in this assay, from the lowest: compounds 4 and 2 (each within the scatter of the next); then compound 1; then compound 3.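

In this assay, the place on a saturated chain carbon bound to an aromatic carbon proves strongly sensitive to the group it carries: 4-(isopropylcarbonyl)piperazin-1-yl in place of 4-aminopiperidin-1-yl gives a 28-fold lower number from compound 3 to compound 4 (1.44 log units; beyond the scatter). The entering group carries no hydrogen-bond donor, so a donor in this group is not needed for a low number. Nothing available explains the size of this step.

The compounds shown leave open whether the piperazine ring or the isopropylcarbonyl group carries the step. They also leave open how an acetyl group or a carboxylic acid on that ring would read.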